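Methoxy for Fluoro: Expected Cytotoxicity of Compound 4

The source may report more compounds than this note shows. Statements on the series, on what has been measured and on what is new or still open speak of the compounds shown alone.

In a toxicity assay on MT4 cells (Homo sapiens) for cytotoxicity, read by MTT assay (on this read-out higher numbers stand for lower toxicity in this test and lower numbers for higher toxicity in this test), compound 2 `Cc1cc(-c2ccc(F)cc2)cc(C)c1Oc1cc(N)nc(Nc2ccc(C#N)cc2)n1` gives 23100 nM, the second highest of the three numbers in hand. Compound 3 `COc1cccc(-c2cc(C)c(Oc3cc(N)nc(Nc4ccc(C#N)cc4)n3)c(C)c2)c1` gives 19300 nM, while compound 1 `Cc1cc(-c2ccc(C#N)c(C#N)c2)ccc1Oc1cc(N)nc(Nc2ccc(C#N)cc2)n1` gives 76700 nM, a higher number lying beyond the scatter. For the measured compounds named here, the one step that connects to this case is a 1.2-fold lower number from compound 2 to compound 3 (0.08 log units; within the scatter), a change that also brought a methoxyphenyl in for the 4-fluorophenyl and produced nothing beyond the scatter. Compound 4 `COc1ccc(-c2cc(C)c(Oc3cc(N)nc(Nc4ccc(C#N)cc4)n3)c(C)c2)cc1` differs from compound 2 by methoxy in place of fluoro on an aromatic carbon. On that single precedent, compound 4 is expected to show a 1.0-fold lower number from compound 2 to compound 4 (0.00 log units; within the scatter), no shift beyond the scatter. Compound 4 is therefore estimated at 23000 nM, within a range from 10000 nM to 50000 nM.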

Compound 4, half-maximal cytotoxic concentration: 10700 nM
The estimate for compound 4 lay 2.1-fold (0.33 log units) above the measured number, within the range that was stated.
By their numbers in this assay, from the lowest: compounds 4, 3 and 2 (each within the scatter of the next, the first and the last beyond it); then compound 1.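

In this assay, methoxy in place of fluoro on this aromatic carbon gives a small step that passes the scatter, a 2.2-fold lower number from compound 2 to compound 4 (0.33 log units; beyond the scatter), which the 3-methoxyphenyl change had not done. The two methoxyphenyl compounds remain within the scatter of each other, a 1.8-fold lower number from compound 3 to compound 4 (0.26 log units; within the scatter), so the placing of the methoxy is not resolved. Nothing available accounts for the shift. On these data alone, whether an amine or a carboxylic acid on this carbon would move the number further remains open, and so does whether a longer chain than methoxy would extend the step.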